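This account rests on a few compounds, and the source may have more. Where it says the series, first, only, none or still open, it means among the compounds named here.

Measured compounds: compound 1 `CNC(=O)[C@@H](c1ccccc1)N1CCn2c(CC3CC3)nc(Cl)c2[C@@H]1CCc1ccc(C(F)(F)F)cc1` gives 35 nM; compound 2 `CCc1nc(C(F)(F)F)c2n1CCN([C@@H](C(=O)NC)c1ccccc1)[C@H]2CCc1ccc(C(F)(F)F)cc1` gives 11 nM; compound 3 `CCOc1nc(CC)n2c1C(CCc1ccc(C(F)(F)F)cc1)N([C@@H](C(=O)NC)c1ccccc1)CC2` gives 2750 nM.

All three numbers come from a functional assay on CHO cells for antagonist activity at Orexin receptor type 2 (Homo sapiens), read by FLIPR and calcium flux; a higher number here means a weaker inhibitor, a lower number a stronger inhibitor. Compound 3 stands highest of the three, with compound 1 the nearest and compound 2 the furthest, both gaps beyond the usual scatter. Compound 4 `CCc1nc(C)c2n1CCN([C@@H](C(=O)NC)c1ccccc1)C2CCc1ccc(C(F)(F)F)cc1` keeps the rest of compound 3 and differs in one place: methyl in place of ethoxy on an aromatic carbon. Going by the values given here, no measured pair isolates this change. Still, compound 1 and compound 2, which carry other small groups at the same ring carbon, both sit far below compound 3, so a step toward lower numbers, well beyond the scatter, is expected from compound 3 to compound 4, a 46-fold lower number from compound 3 to compound 4 (1.66 log units; beyond the scatter). Compound 4 is therefore estimated at 60 nM, with a range from 10 nM to 400 nM.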

Compound 4, half-maximal inhibitory concentration: 24 nM
Beside the measured number, compound 4's estimate is 2.5-fold (0.40 log units) above it, and the stated range covers the measured number.
By their numbers in this assay, from the lowest: compound 2; then compounds 4 and 1 (each within the scatter of the next); then compound 3.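

Replacing ethoxy with methyl on this aromatic carbon gives a 110-fold lower number from compound 3 to compound 4 (2.06 log units; beyond the scatter) in this assay. Going by these compounds alone, this is the first step that isolates the group at this position, and it ties the high number of compound 3 to the ethoxy rather than to the rest of the shared core. Nothing available explains why the step is so large.

The compounds shown leave open whether a methoxy, a hydroxyl or an amine at this carbon would sit with compound 4 or with compound 3.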